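Benzyl for Butoxy: What the Next Growth Value May Show

This account rests on a few compounds, and the source may have more. Where it says the series, first, only, none or still open, it means among the compounds named here.

Measured compounds:
compound 1 `CCCCOc1ccc(NC(=O)n2nc(N)c3ccccc32)cc1` — 13900 nM
compound 2 `Nc1nn(C(=O)Nc2c(F)cccc2F)c2ccccc12` — < 100000 nM

Among the compounds with values here, in a functional assay on COLO 205 cells (Homo sapiens) for inhibition, read by sulforhodamine B assay, with a stated time of 48 h (on this read-out lower numbers stand for stronger inhibition of growth and higher numbers for weaker inhibition of growth), compound 1 gives 13900 nM, the only number among the values shown. Compound 2 shows in this assay only a limit, < 100000 nM (the limit of < 100000 nM in this assay, at which 1 of the 2 values shown sits). Compound 3 `Nc1nn(C(=O)Nc2ccc(Cc3ccccc3)cc2)c2ccccc12` differs from compound 1 by benzyl in place of butoxy on an aromatic carbon. Within the data shown here, no step between measured compounds exists to guide the size of this change, so only a modest shift in this assay is expected, likely within the scatter. For compound 3 the estimate is 10000 nM, within 3000 nM to 40000 nM, an expected step of a 1.4-fold lower number from compound 1 to compound 3 (0.14 log units; within the scatter).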

Compound 3, concentration for 50% growth inhibition: 13400 nM
Beside the measured number, compound 3's estimate is 1.3-fold (0.13 log units) below it; low and high end bracket the measured number.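

In this assay, benzyl in place of butoxy gives a 1.0-fold lower number from compound 1 to compound 3 (0.02 log units; within the scatter), the first step read at this position, on an aromatic carbon para to a large group. Butoxy, with no ring, and benzyl, with one six-membered aromatic ring of carbon only and no hydrogen-bond acceptor, thus read alike here, so neither the ring nor the loss of the acceptor moves the value beyond the scatter. Nothing measured here gives a cause for this result. On these data alone, whether an amine or a carboxylic acid at this position would read alike stays open. So does the effect of a longer chain in place of butoxy.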